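A few compounds are considered here, and "the series" means these few. Any claim that something is new, unique, unknown or untested is made for them only; others in the source may bear on it.

Working notes on the series. Compound 3 `O=C(Nc1cccc(-c2oc3cc(-c4ccc(F)cc4)ccc3c(=O)c2O)c1)c1ccc(Cl)nc1` carries the lowest number of the three measured in a functional assay on HCC1937 cells (Homo sapiens) for antiproliferative activity, read by CCK-8 assay, with a stated time of 72 h (a higher number here means a weaker inhibitor, a lower number a stronger inhibitor), at 7550 nM. Compound 2 `Cc1cccc(C(=O)Nc2cccc(-c3oc4cc(-c5ccc(F)cc5)ccc4c(=O)c3O)c2)c1` gives 8030 nM in this assay, and compound 1 `COc1cccc(C(=O)Nc2cccc(-c3oc4cc(-c5ccc(F)cc5)ccc4c(=O)c3O)c2)c1` gives 18900 nM. The steps among them read a 2.4-fold lower number from compound 1 to compound 2 (0.37 log units; beyond the scatter), a 2.5-fold lower number from compound 1 to compound 3 (0.40 log units; beyond the scatter) and a 1.1-fold lower number from compound 2 to compound 3 (0.03 log units; within the scatter). Compound 4 `CCCc1ccc(C(=O)Nc2cccc(-c3oc4cc(-c5ccc(F)cc5)ccc4c(=O)c3O)c2)cc1` is the next case: 4-propylphenyl in place of 6-chloropyridin-3-yl on a carbonyl carbon. All three measured steps exchange the group on the carbonyl carbon and all stay modest, so the next exchange is expected to stay modest as well, with no firm direction. The estimated step is a 1.1-fold higher number from compound 3 to compound 4 (0.03 log units; within the scatter). Compound 4 is therefore expected near 8000 nM in this assay, within roughly 3000 nM to 20000 nM.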

Compound 4, half-maximal inhibitory concentration: 15400 nM
Compound 4: middle estimate off by 1.9-fold (0.28 log units), on the low side, and the stated range covers the measured number.
By their numbers in this assay, from the lowest: compounds 3, 2, 4 and 1 (each within the scatter of the next, the first and the last beyond it).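

In this assay, within the data shown here, the exchange to 4-propylphenyl on the carbonyl carbon gives a 2.0-fold higher number from compound 3 to compound 4 (0.31 log units; beyond the scatter), the only new step beyond the scatter. Against the other two groups, a 1.9-fold higher number from compound 2 to compound 4 (0.28 log units; within the scatter) and a 1.2-fold lower number from compound 1 to compound 4 (0.09 log units; within the scatter) leave compound 4 level with both, so a ring of carbon only bearing a propyl chain does not separate from the 3-methylphenyl or 3-methoxyphenyl compounds. Nothing available explains the step away from 6-chloropyridin-3-yl.

As far as these compounds go, whether an amine or a carboxylic acid on this ring, or a chain longer than propyl, would move the number beyond this modest span remains open.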